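Taking a Methoxy Group Off Compound 1

The source may hold more compounds than are shown below. What is called first, only, known or untested is meant among the compounds shown, and "the series" means these compounds.

Within the data shown here, in a functional assay on HCT-8 cells (Homo sapiens) for antiproliferative activity, read by MTT assay, with a stated time of 48 h (on this read-out lower numbers stand for stronger inhibition and higher numbers for weaker inhibition), compound 1 `COc1ccc2c(/C=C/C(=O)c3cc(OC)c(OC)c(SC)c3)c[nH]c2c1` gives 138 nM, the lower of the two numbers measured so far, while compound 2 `COc1ccc2c(/C=C/C(=O)c3cc(N)c(OC)c(OC)c3)c[nH]c2c1` gives 368 nM. Compound 3 `COc1cc(C(=O)/C=C/c2c[nH]c3ccccc23)cc(SC)c1OC` has not yet been measured. It differs from compound 1 as follows: hydrogen in place of methoxy on an aromatic carbon. Among the measured compounds shown here, no measured step touches this methoxy. For the measured compounds named here, the only guide is a 2.7-fold higher number from compound 1 to compound 2 (0.43 log units; beyond the scatter), a modest step with amino in place of methylsulfanyl at a different place, so it bears on the size of the change only indirectly. Nothing shows the direction, but compound 1 already holds the lower number, so a modest rise seems more likely than a fall. The expected step is a 2.5-fold higher number from compound 1 to compound 3 (0.40 log units; beyond the scatter). For compound 3 the estimated value is 350 nM, with an expected range from 100 nM to 1200 nM.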

Compound 3, half-maximal inhibitory concentration: 167 nM
The estimate for compound 3 lay 2.1-fold (0.32 log units) above the measured number; measured number inside the range.
By their numbers in this assay, from the lowest: compounds 1 and 3 (each within the scatter of the next); then compound 2.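

Hydrogen in place of methoxy on this aromatic carbon gives, in this assay, a 1.2-fold higher number from compound 1 to compound 3 (0.08 log units; within the scatter), so at this position the methoxy can go without the number leaving the scatter around compound 1. The only earlier step, at a different place, was a 2.7-fold higher number from compound 1 to compound 2 (0.43 log units; beyond the scatter) and lay beyond the scatter, whereas this position has so far shown no step beyond it. Nothing at hand accounts for this result.

As far as these compounds go, whether a larger group on this carbon, such as an ethoxy, a longer alkoxy chain or an amine, would also stay within the scatter remains open. Also open, from the compounds shown here alone, is whether hydrogen here would give the same result with the amino group of compound 2 in place of the methylsulfanyl.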